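This account rests on a few compounds, and the source may have more. Where it says the series, first, only, none or still open, it means among the compounds named here.

In a functional assay on B16-F10 cells (Mus musculus) for antiproliferative activity, read by MTT assay, with a stated time of 72 h (on this read-out higher numbers stand for weaker inhibition and lower numbers for stronger inhibition), compound 1 (`CCCCCCCCCNC[C@@H]1OC[C@H](N)[C@H]1O`) gives > 128000 nM as a limit and not a number. For the measured compounds named here, compound 2 (`CCCCCCCCCCCCNC[C@@H]1OC[C@H](N)[C@@H]1O`) gives 10700 nM as the only actual number so far, which makes it the single firm reference point. Compound 3 (`CCCCCCCCCNC[C@@H]1OC[C@H](N)[C@@H]1O`) differs from compound 2 in one place, on a saturated chain carbon, nine bonds along the chain from an amine nitrogen. There, hydrogen in place of propyl on a saturated chain carbon, nine bonds along the chain from an amine nitrogen sums up the change, which in words is hydrogen in place of propyl. Going by the values given here, no pair of measured compounds shows what a change of this kind does, so the expectation rests on the shortened chain and on compound 2 with its 10700 nM as the starting point. In this assay the expectation is a step towards weaker inhibition, larger than the usual scatter of repeated measurements. Among the compounds with values here, the expected step of a 4.2-fold higher number from compound 2 to compound 3 (0.62 log units; beyond the scatter) is an estimate with wide margins, since it has no measured step to lean on. Compound 3 is expected to give about 45000 nM with an estimated range of 18000 nM to 120000 nM in this test.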

Compound 3, half-maximal inhibitory concentration: 55200 nM
The estimate for compound 3 lay 1.2-fold (0.09 log units) below the measured number; measured number inside the range.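

Removing the propyl end of the chain has a measurable cost in this assay, with a 5.2-fold higher number from compound 2 to compound 3 (0.71 log units; beyond the scatter), so in this pair the outer chain carbons make a difference that exceeds the usual scatter. Compound 1 gives > 128000 nM, which is a limit and not a number. Configuration matters as well, and the step of an at least 2.3-fold lower number from compound 1 to compound 3 (0.36 log units; beyond the scatter) can be assigned to a single stereocentre at a saturated ring carbon because nothing else changes: the fact that compounds 1 and 3 differ only in the configuration as drawn

The compounds shown give only the effect of this one shortening, so they cannot tell whether activity changes smoothly with chain length, or whether a still longer chain would lower the number further. As far as these compounds go, it also remains open whether the configuration drawn in compound 1 would weaken inhibition to a similar degree when paired with the longer chain of compound 2, and what a hydroxyl group or a carboxylic acid at the end of the chain would do.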